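The source may hold more compounds than are shown below. What is called first, only, known or untested is meant among the compounds shown, and "the series" means these compounds.

Measured so far:
- compound 1, `Cc1cc(-n2ccnc2)cn2c(CSCCc3ccccc3)cnc12`: 100 ug/mL
- compound 2, `Cc1cc(-n2ccc3ccccc32)cn2c(CSCCc3ccccc3)cnc12`: > 20 ug/mL
- compound 3, `Cc1cc(-n2ccnc2)c2ncc(CSCCc3ccccc3)n2c1`: 20 ug/mL

All three were tested in an ADME assay on HEL cells (Homo sapiens) for cytotoxicity, with a stated time of 3 days; a lower number here means that less compound is tolerated, a higher number that more compound is tolerated. In this assay compound 1 gives 100 ug/mL. For compound 2 the result is a limit of the assay, > 20 ug/mL, and not a number. Compound 3 gives 20 ug/mL in this assay; against compound 1 this is a lower number, a gap beyond the usual scatter. Compound 3 and compound 1 have the same atoms joined differently; the difference between the two cores is not broken down here.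

From compound 1 to compound 2 the change is 1H-indol-1-yl in place of 1H-imidazol-1-yl on an aromatic carbon. The step it made, a step that the limit leaves unreadable from compound 1 to compound 2, cannot be read because of the limit of > 20 ug/mL in this assay, at which 1 of the 3 values shown sits.

Compound 4, `Cc1cc(-n2ccc3ccccc32)c2ncc(CSCCc3ccccc3)n2c1`, has not yet been measured. It differs from compound 3 by 1H-indol-1-yl in place of 1H-imidazol-1-yl on an aromatic carbon. This is the same kind of change as from compound 1 to compound 2, but not the same: in compound 4 the group sits ortho to a fused ring, whereas in compound 2 it sits para to a fused ring.

The expectation for compound 4 rests on compound 3 with 20 ug/mL and on the unreadable step that the limit leaves unreadable from compound 1 to compound 2, which gives no direction. The expected step is no change at the digits printed from compound 3 to compound 4 (within the scatter), so compound 4 is estimated at 20 ug/mL, between 5 ug/mL and 80 ug/mL.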

Compound 4, minimum cytotoxic concentration: 100 ug/mL
The estimate for compound 4 lay 5.0-fold (0.70 log units) below the measured number, and the stated range ends below it.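

In this assay, placing 1H-indol-1-yl instead of 1H-imidazol-1-yl on the core of compound 3 gives a 5.0-fold higher number from compound 3 to compound 4 (0.70 log units; beyond the scatter), so on this core the compound with the larger group is tolerated at a higher concentration. This is one step on one core, so it does not show that the change has the same effect wherever it is made, and the group also sits in a different place on the two cores. The matching step on the core of compound 1 cannot be read, so the two steps cannot be compared, because compound 2 gives a limit of the assay and not a number: the limit of > 20 ug/mL in this assay, at which 1 of the 4 values shown sits.

A number for compound 2 in place of its limit would be needed to show whether the step carries over to the core of compound 1. The compounds shown also leave open how other groups in this place, such as an amine or a carboxylic acid, would behave on either core, and what a longer chain in place of the shared sulfur-linked side chain would do.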